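A Dimethylimidazole Replaces the Aminotriazole of Compound 1

The source may hold more compounds than are shown below. What is called first, only, known or untested is meant among the compounds shown, and "the series" means these compounds.

Compound 1 `CC(C)C(Nc1nnc[nH]1)c1ccc(-c2ccc3cccc(F)c3c2)[nH]c1=O` gives 2.42 h
Compound 2 `CCn1ncc2c(F)cc(-c3ccc(C(CC)(CC)c4nnc[nH]4)c(=O)[nH]3)cc21` gives > 3 h (a limit)
Compound 3 `CCC(CC)(c1nnc[nH]1)c1ccc(-c2ccc3cccc(F)c3c2)[nH]c1=O` gives 0.447 h

All three compounds were tested in an ADME assay on microsomes from liver (Mus musculus) for metabolic stability (on this read-out lower numbers stand for a shorter-lived compound and higher numbers for a longer-lived compound), and compound 1 stands at 2.42 h there, the higher of the two actual numbers. Compound 3 gives 0.447 h in the same test, and the gap between these two compounds lies beyond the scatter. Compound 2 shows > 3 h as a limit of the assay and not a number.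

Compound 4 `Cc1nc(C(c2ccc(-c3ccc4cccc(F)c4c3)[nH]c2=O)C(C)C)[nH]c1C` has not yet been measured and differs from compound 1 by a single change 4,5-dimethyl-1H-imidazol-2-yl in place of (4H-1,2,4-triazol-3-yl)amino on a saturated chain carbon bound to an aromatic carbon and a saturated chain carbon with 4,5-dimethyl-1H-imidazol-2-yl in place of (4H-1,2,4-triazol-3-yl)amino on a saturated chain carbon bound to an aromatic carbon and a saturated chain carbon.

Going by the values given here, no pair of measured compounds shows this change on its own, so any forecast is uncertain. Among the compounds with values here, a drop in this assay is expected rather than a gain, resting on compound 3 with 0.447 h as the only other actual number in the set. The expected size of the move is a 2.4-fold lower number from compound 1 to compound 4 (0.38 log units; beyond the scatter) as a shortening that only just clears the scatter. For compound 4 the estimate is 1 h with an expected range from 0.3 h to 3 h in this test.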

Compound 4, half-life: 0.0817 h
Beside the measured number, compound 4's estimate is 12-fold (1.09 log units) above it, outside the stated range (below it).
By their numbers in this assay, from the lowest: compound 4; then compound 3; then compound 1. At a limit, above all of these: compound 2.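

In this assay, going by these compounds alone, the single change at this position now has a direct reading: a 30-fold lower number from compound 1 to compound 4 (1.47 log units; beyond the scatter), a large step with the rest of the structure of compound 1 kept. The earlier compounds shown here held no such pair, so they could not show that the group on this saturated chain carbon, bound to an aromatic carbon and a saturated chain carbon, can by itself move the half-life this far, or that 4,5-dimethyl-1H-imidazol-2-yl is a poor replacement here for (4H-1,2,4-triazol-3-yl)amino. Nothing measured in this set accounts for the size of the step.

The compounds shown leave open which part of the swap carries the loss: the removed amino link, the ring with 2 hetero atoms in place of the ring with 3, or the two methyl groups on the new ring. As far as these compounds go, a 1H-imidazol-2-yl without those methyl groups, or a 1H-imidazol-2-ylamino group at the same carbon, would pull these parts apart, and it also remains open whether the same swap would do the same on another core.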